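Swapping a bulky sulfonyl substituent back for a small amine

The source may hold more compounds than are shown below. What is called first, only, known or untested is meant among the compounds shown, and "the series" means these compounds.

Three ureas sharing one core have been measured in an assay on isolated protein for activation of Nicotinamide phosphoribosyltransferase (Homo sapiens); on this read-out higher numbers stand for an effect only at larger amounts of compound and lower numbers for an effect already at smaller amounts. Compound 1 `CNS(=O)(=O)c1ccc(NC(=O)NCc2ccncc2)cc1` carries a methylamino group on the sulfonyl sulfur and gives 3230 nM. Compound 2 `O=C(NCc1ccncc1)Nc1ccc(S(=O)(=O)c2ccc(Cl)cc2)cc1` gives 126 nM, and compound 3 `O=C(NCc1ccncc1)Nc1ccc(S(=O)(=O)N2CCc3ccccc3C2)cc1` gives 142 nM. Compound 3 therefore sits next to compound 2, the two lying within the scatter of each other (a 1.1-fold higher number from compound 2 to compound 3 (0.05 log units; within the scatter)), while both stand far from compound 1: the change from compound 1 to compound 3 brought a 23-fold lower number from compound 1 to compound 3 (1.36 log units; beyond the scatter), and that from compound 1 to compound 2 brought a 26-fold lower number from compound 1 to compound 2 (1.41 log units; beyond the scatter).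

Compound 4 `CN(C)S(=O)(=O)c1ccc(NC(=O)NCc2ccncc2)cc1` has not yet been measured. It differs from compound 3 by dimethylamino in place of 1,2,3,4-tetrahydroisoquinolin-2-yl on a sulfonyl sulfur. This returns the sulfonyl substituent to something very close to what compound 1 carries, a small amine in place of a ring-bearing group, so the step from compound 1 to compound 3 is the one that bears on it, read in reverse. Because compound 1 gives 3230 nM, a large rise in the number is expected for compound 4, on the order of a 14-fold higher number from compound 3 to compound 4 (1.15 log units; beyond the scatter). The estimate for compound 4 in this assay is 2000 nM, with a likely range from 600 nM to 6000 nM.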

Compound 4, half-maximal effective concentration: 3110 nM
Compound 4: middle estimate off by 1.6-fold (0.19 log units), on the low side, and the stated range covers the measured number.
By their numbers in this assay, from the lowest: compounds 2 and 3 (each within the scatter of the next); then compounds 4 and 1 (each within the scatter of the next).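

In this assay, the change of substituent on the sulfonyl sulfur gives a 22-fold higher number from compound 3 to compound 4 (1.34 log units; beyond the scatter), and this separates two things that differed together between compound 1 and compound 3: the hydrogen on the sulfonamide nitrogen and the ring-bearing group. Compound 4 has no such hydrogen, just like compound 3, yet the methyl added to compound 1 leaves the result within the scatter, at a 1.0-fold lower number from compound 1 to compound 4 (0.02 log units; within the scatter), so removing that hydrogen does not by itself bring the low number. Replacing the 4-chlorophenyl group of compound 2 with dimethylamino gives a 25-fold higher number from compound 2 to compound 4 (1.39 log units; beyond the scatter), so among these four compounds, the two low numbers belong to the substituents with aromatic rings, and no compound goes against this.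

Still open, from the compounds shown here alone, is whether the aromatic ring is needed at all, or whether a piperidin-1-yl group or a longer chain such as dipropylamino on the sulfonyl sulfur would also give a low number. Nothing available here explains why the ring-bearing groups give the lower numbers.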